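Cytotoxicity notes on the shared core series

The source may report more compounds than this note shows. Statements on the series, on what has been measured and on what is new or still open speak of the compounds shown alone.

Measured so far in an ADME assay on cells (Fibroblast, Gallus gallus) for cytotoxicity, read by CCK-8 assay, with a stated time of 48 h; on this read-out higher numbers stand for lower toxicity in this test and lower numbers for higher toxicity in this test:
compound 1 `CCC(CC)O[C@@H]1C=C(C(=O)O)C[C@H](NCc2ccc(OC)cc2)[C@H]1NC(C)=O`: > 200000 nM
compound 2 `CCC(CC)O[C@@H]1C=C(C(=O)O)C[C@H](NCc2ccc(SC3CCCCC3)cc2)[C@H]1NC(C)=O`: > 200000 nM

In this assay compound 1 gives > 200000 nM, which is a limit of the assay and not a number. Compound 2 gives > 200000 nM in this assay, likewise a limit and not a number. Compound 2 therefore stands at the limit, the same position as compound 1, as recorded by the limit of > 200000 nM in this assay, at which 2 of the 2 values shown sit. The step that the two limits leave unreadable from compound 1 to compound 2 cannot be read, since both of its ends are limits.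

Compound 3 `CCC(CC)O[C@@H]1C=C(C(=O)O)C[C@H](NCc2ccc(-c3csc4ccccc34)cc2)[C@H]1NC(C)=O` is not yet measured. It differs from compound 2 by 1-benzothiophen-3-yl in place of cyclohexylsulfanyl on an aromatic carbon. Among the compounds with values here, the only measured step, the one from compound 1 to compound 2, bears on this change as another replacement on the same aromatic carbon, but its size is not readable, so no step of known size is available. With both measured values sitting at the limit (the limit of > 200000 nM in this assay, at which 2 of the 2 values shown sit), no movement beyond the scatter is expected for compound 3, and the estimated step is a step that the limit leaves unreadable from compound 2 to compound 3. Compound 3 is expected to give about 250000 nM, within a range from 120000 nM to 500000 nM, most likely again reported only as a limit.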

Compound 3, half-maximal cytotoxic concentration: > 200000 nM
Compound 3: only a limit was reported; the forecaster's own chance of this, stated with the estimate: 85%; the middle value is on the limit's open side.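

Compound 3 also gives only a limit of the assay in this assay, so no step among compound 1, compound 2 and compound 3 can be read: the limit of > 200000 nM in this assay, at which 3 of the 3 values shown sit.

The compounds shown leave open where each of the three truly lies and whether any of these replacements on the aromatic carbon alters this read-out.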